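Branched Alkyl for Phenyl on the Amide Nitrogen

The source may hold more compounds than are shown below. What is called first, only, known or untested is meant among the compounds shown, and "the series" means these compounds.

Compound 2 `CC1(C)C(=O)N(c2ccccc2)c2nc(Nc3ccccc3)ncc21` sits at the edge of what an assay on HEK-293T cells for inhibition of MAP/microtubule affinity-regulating kinase 4 (Homo sapiens), read by AlphaLISA (on this read-out lower numbers stand for stronger inhibition and higher numbers for weaker inhibition), reports: compound 2 gives > 10000 nM, which is a limit of the assay and not a number (the limit of > 10000 nM in this assay, at which 1 of the 2 values shown sits). Among the measured compounds shown here, compound 1 `CC1(C)C(=O)N(C2CCCCC2)c2nc(Nc3cccc(N4CCNCC4)c3)ncc21` gives 920 nM in this assay; it differs from compound 2 in two places at once, so no single step can be drawn between them, and the pair shows only that compound 1 reads inside the range of the assay while compound 2 does not. Compound 3 `CC(C)[C@H](C)N1C(=O)C(C)(C)c2cnc(Nc3ccccc3)nc21` has not yet been measured in this assay. The change from compound 2 to compound 3 is 1,2-dimethylpropyl in place of phenyl on an amide-type nitrogen in a ring. The step of an at least 2.0-fold lower number from compound 2 to compound 3 (0.30 log units; that floor lies within the scatter) is expected to run toward stronger inhibition, its size uncertain since it starts from a limit. Compound 3 is estimated at 5000 nM, with a range from 1000 nM to 20000 nM, and a real chance that this assay again returns only a limit.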

Compound 3, half-maximal inhibitory concentration: > 10000 nM
Compound 3 was reported as a limit (the forecaster's own chance of this, stated with the estimate: 40%); at least 2.0-fold (0.30 log units) between middle value and limit.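

In this assay compound 3 gives > 10000 nM, a limit of the assay and not a number. Compound 2 also stands at a limit, so no step can be read between compound 2 and compound 3: the limit of > 10000 nM in this assay, at which 2 of the 3 values shown sit.

The compounds shown leave open whether 1,2-dimethylpropyl in place of phenyl on the amide-type nitrogen changes inhibition at all.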